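The compounds below may be only part of what the source reports. "The series", "measured", "known", "first", "only" and "open" are said of these compounds alone.

Compound 1, `CCCCNc1nc(N)nc2c1CN(Cc1ccccn1)CC2`: 0.07 uM
Compound 2, `CCCCNc1nc(N)nc2c1CN(C(=O)c1ccncc1)CC2`: > 25 uM
Compound 3, `CCCCNc1nc(N)nc2c1CN(C(=O)c1csc(N)n1)CC2`: not yet measured

In an assay on HEK293 cells for agonist activity at Toll-like receptor 8 (Homo sapiens), read by a luciferase reporter, with a stated time of 6 h (a higher number here means that more compound is needed for the effect, a lower number that less compound is needed), compound 1 gives 0.07 uM. For compound 2 the reading of > 25 uM is a limit of this assay and not a number, so compound 2 stands at the weak end of what has been measured (the limit of > 25 uM in this assay, at which 1 of the 2 values shown sits). For the measured compounds named here, the only measured step is an at least 350-fold higher number from compound 1 to compound 2 (2.55 log units; beyond the scatter), which goes with the exchange of (pyridin-2-yl)methyl for (pyridin-4-yl)carbonyl on the amine nitrogen in a ring. Compound 3 keeps that carbonyl and differs from compound 2 in one place: 2-amino-1,3-thiazol-4-yl in place of pyridin-4-yl on a carbonyl carbon. Going by the values given here, no measured step bears on this exchange of ring directly; the step from compound 1 to compound 2 bears on it only in that the carbonyl of compound 2 remains in compound 3. Compound 3 is therefore expected to stay near the limit, with a step that the limit leaves unreadable from compound 2 to compound 3 and nothing beyond the scatter. Compound 3 is estimated at 30 uM, within 5 uM to 100 uM.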

Compound 3, minimum effective concentration: 6.9 uM
For compound 3 the middle estimate is 4.3-fold (0.64 log units) above the measured one, within the range that was stated.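

In this assay, the exchange of pyridin-4-yl for 2-amino-1,3-thiazol-4-yl on the carbonyl carbon gives an at least 3.6-fold lower number from compound 2 to compound 3 (0.55 log units; beyond the scatter), so a carbonyl on this amide-type nitrogen in a ring does not by itself hold a compound at the limit. Going by these compounds, the true size of that step stays unknown, as compound 2 gives a limit of the assay and not a number: the limit of > 25 uM in this assay, at which 1 of the 3 values shown sits. Even so, (2-amino-1,3-thiazol-4-yl)carbonyl in place of (pyridin-2-yl)methyl still leaves a 99-fold higher number from compound 1 to compound 3 (1.99 log units; beyond the scatter), so the large step seen with compound 2 is only partly recovered.

The compounds shown leave open whether the lower number belongs to the amino group or to the thiazole ring itself, a question that a plain 1,3-thiazol-4-yl group would address. They also leave open how (2-amino-1,3-thiazol-4-yl)methyl, with a methylene in place of the carbonyl, would compare with compound 1.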